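This account rests on a few compounds, and the source may have more. Where it says the series, first, only, none or still open, it means among the compounds named here.

Compound 1 `CCCCn1nc(C(=O)N[C@H]2COc3ccccc3N(C)C2=S)nc1Cc1ccccc1` gives 510 nM in a functional assay on HT-29 cells (Homo sapiens) for inhibition, read by luminescence and CellTiter-Glo, with a stated time of 24 h; on this read-out lower numbers stand for an effect already at smaller amounts and higher numbers for an effect only at larger amounts of compound.
Compound 2 `CN1C(=S)[C@@H](NC(=O)c2nc(Cc3ccccc3)n(CCCO)n2)COc2ccccc21` gives 209 nM in this assay.
Compound 3 `CN1C(=S)[C@@H](NC(=O)c2nc(Cc3ccccc3)n(C3CCCCCC3)n2)COc2ccccc21` gives 5530 nM in this assay.

The three compounds share one core and differ only in the group on an aromatic nitrogen of the five-membered ring. Compound 3, which carries a cycloheptyl there, stands at the highest number of the three: an 11-fold higher number from compound 1 to compound 3 (1.04 log units; beyond the scatter) and a 26-fold higher number from compound 2 to compound 3 (1.42 log units; beyond the scatter). In other words, swapping a chain for a cycloheptyl at this position weakened the effect sharply in both cases that were measured, while the smaller change between the two chains was only modest (a 2.4-fold lower number from compound 1 to compound 2 (0.39 log units; beyond the scatter)).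

Compound 4 `CN1C(=S)[C@@H](NC(=O)c2nc(Cc3ccccc3)n(-c3ncccn3)n2)COc2ccccc21` is not yet measured. It differs from compound 3 in one place: pyrimidin-2-yl in place of cycloheptyl on an aromatic nitrogen. The cycloheptyl that went with the weakest result is thus removed, and a smaller aromatic ring takes its place. The two steps that introduced the cycloheptyl are the ones that bear on this change, and both were large and in the direction of weaker effect. Reversing the cycloheptyl is therefore expected to bring a large step back toward lower numbers in this assay, although no measured compound shows how an aromatic ring rather than a chain behaves at this spot, so the expectation is rough. For compound 4 the estimate is 500 nM, within a range of 120 nM to 2500 nM, which would mean an expected step of an 11-fold lower number from compound 3 to compound 4 (1.04 log units; beyond the scatter).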

Compound 4, half-maximal effective concentration: 3970 nM
The estimate for compound 4 lay 7.9-fold (0.90 log units) below the measured number; the whole stated range lies below it.
By their numbers in this assay, from the lowest: compound 2; then compound 1; then compounds 4 and 3 (each within the scatter of the next).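

Taking away the cycloheptyl did not by itself bring the effect back in this assay: with pyrimidin-2-yl on the aromatic nitrogen the result is a 1.4-fold lower number from compound 3 to compound 4 (0.14 log units; within the scatter), so the two ring-bearing compounds cannot be told apart. Both chains still give lower numbers than the pyrimidin-2-yl group, with a 19-fold higher number from compound 2 to compound 4 (1.28 log units; beyond the scatter) and a 7.8-fold higher number from compound 1 to compound 4 (0.89 log units; beyond the scatter), so among these four compounds, both groups attached through a ring sit on the high side and both open chains on the low side, with no compound going against this split. The two ring groups also differ sharply in make-up, one a seven-membered ring of carbon only with no hydrogen-bond acceptors and the other a six-membered aromatic ring with two nitrogens and two acceptors, yet this difference shows no readable effect on the number here.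

No measurement in hand explains why the chains and the rings separate in this way. Going by these compounds, it remains open whether a small cyclopropyl ring, a shorter ethyl chain or a propyl chain ending in an amine or a carboxylic acid would fall with the chains or with the rings.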